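The source may hold more compounds than are shown below. What is called first, only, known or untested is meant among the compounds shown, and "the series" means these compounds.

Compound 1 `C#CCN(C)Cc1cccc(NC(=O)CCCCC(=O)NO)c1` gives 9750 nM in a functional assay on DU-145 cells (Homo sapiens) for inhibition, read by MTT assay, with a stated time of 48 h; a lower number here means a stronger inhibitor of growth, a higher number a weaker inhibitor of growth. Compound 2 `C#CCN(C)Cc1cccc(NC(=O)CCCCCCCC(=O)NO)c1` gives 3780 nM in this assay.

Compound 2 stands lowest of the two numbers. Among the measured compounds shown here, the one measured step, a 2.6-fold lower number from compound 1 to compound 2 (0.41 log units; beyond the scatter), was modest. Compound 3 `C#CCN(C)Cc1cccc(NC(=O)CCCCCCCCC(=O)NO)c1` continues the same chain lengthening, by a single carbon this time: (hydroxycarbamoyl)methyl in place of hydroxycarbamoyl on a saturated chain carbon, seven bonds along the chain from a carbonyl carbon. Since that earlier lengthening of three carbons gave only a modest gain, a single added carbon is expected to move the number in this assay only slightly, toward a lower value and probably within the scatter. Compound 3 is therefore expected at 2900 nM, within 1500 nM to 5500 nM. The expected step is a 1.3-fold lower number from compound 2 to compound 3 (0.12 log units; within the scatter).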

Compound 3, concentration for 50% growth inhibition: 2940 nM
Compound 3: middle estimate off by 1.0-fold (0.01 log units), on the low side; measured number inside the range.
By their numbers in this assay, from the lowest: compounds 3 and 2 (each within the scatter of the next); then compound 1.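

In this assay, the single added carbon gives a 1.3-fold lower number from compound 2 to compound 3 (0.11 log units; within the scatter), so at this position (hydroxycarbamoyl)methyl in place of hydroxycarbamoyl cannot be told apart from the shorter chain. The larger change, 4-(hydroxycarbamoyl)butyl in place of hydroxycarbamoyl, gives a 3.3-fold lower number from compound 1 to compound 3 (0.52 log units; beyond the scatter), so across these compounds a clear gain appears only over the full lengthening. Nothing measured here explains how chain length affects growth inhibition.

On these data alone, whether a longer chain would hold this level remains open. So does the effect of a carboxylic acid in place of the hydroxycarbamoyl end.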